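Ester-linked thiazolium exchanged for an ether-linked methylthiazolium

The source may report more compounds than this note shows. Statements on the series, on what has been measured and on what is new or still open speak of the compounds shown alone.

Within the data shown here, compound 2 `CCCCCCCCCCCCCCCCCC1OCC(COC(=O)CCCCC[n+]2ccsc2)O1` is the only compound here with a numerical result: in a functional assay on artery with platelet-activating factor receptor (Rattus norvegicus) as the target (a higher number here means that more compound is needed for the effect, a lower number that less compound is needed), compound 2 gives 0.88 mg/kg. Compound 1 `CCCCCCCCCCCCCCCCCC1OCC(COCCCCCC[N+](C)(C)C)O1` reaches only a limit of the assay, > 5 mg/kg, which is not a number. Compound 3 `CCCCCCCCCCCCCCCCCC1OCC(COCCCCCC[n+]2cscc2C)O1` has not been measured. It differs from compound 2 in one place: a group of 12 heavy atoms (10 carbon, 1 nitrogen, 1 sulfur; one five-membered aromatic ring with 2 hetero atoms) in place of a group of 12 heavy atoms (9 carbon, 1 nitrogen, 1 oxygen, 1 sulfur; one five-membered aromatic ring with 2 hetero atoms), on an oxygen on a saturated carbon. Among the measured compounds shown here, only one measured step exists, an at least 5.6-fold lower number from compound 1 to compound 2 (0.75 log units; beyond the scatter), and it altered both the charged head and the link to the oxygen at once, so it bears on the present change only loosely. It does show that the trimethylammonium-bearing compound sits at the limit of > 5 mg/kg in this assay, at which 1 of the 2 values shown sits. Compound 3 keeps a thiazolium-type ring yet returns to the ether link, so a step of a 1.5-fold higher number from compound 2 to compound 3 (0.17 log units; within the scatter) is expected, within the usual scatter. Compound 3 is estimated at 1.3 mg/kg in this assay, from 0.4 mg/kg to 4.5 mg/kg.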

Compound 3, dose for 50% inhibition: 3.1 mg/kg
Compound 3: middle estimate off by 2.4-fold (0.38 log units), on the low side, and the stated range covers the measured number.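

On the oxygen on a saturated carbon, exchanging the ester-linked thiazolium for the ether-linked methylthiazolium is not a neutral change in this assay: it gives a 3.5-fold higher number from compound 2 to compound 3 (0.55 log units; beyond the scatter), so more compound is needed for the effect. With the ether link kept, replacing the trimethylammonium end with the methylthiazolium ring gives an at least 1.6-fold lower number from compound 1 to compound 3 (0.20 log units; that floor lies within the scatter), so this pair does not establish that the ring alone lowers the dose. Compound 1 still gives only a limit of the assay, not a number: the limit of > 5 mg/kg in this assay, at which 1 of the 3 values shown sits.

The step from compound 2 to compound 3 removes the carbonyl and adds the ring methyl together, and the compounds shown do not separate these two changes. An ether-linked thiazolium without the methyl, or an ester-linked methylthiazolium, would bear on each change alone.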